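Replacing 4-fluorophenyl by 3-phenylpropyl on the chain carbon

The source may report more compounds than this note shows. Statements on the series, on what has been measured and on what is new or still open speak of the compounds shown alone.

Measured compounds:
Compound 1 `Nc1nc(NCc2ccc(F)cc2)nc(-c2ccccc2CO)n1`: 3.97
Compound 2 `Nc1nc(NCc2ccc(F)cc2)nc(-c2c(F)cccc2CO)n1`: 4.45

In a functional assay on cells for positive allosteric modulation of G-protein coupled receptor 68 (Homo sapiens), read by a luciferase reporter and cAMP accumulation, with a stated time of 30 min, at pH 6.8 and pH 8.3, in the presence of a further agent that is not named here (a lower number here means a less potent compound, a higher number a more potent compound, by a factor of ten per unit of this negative logarithm), compound 2 gives 4.45, the higher of the two numbers measured. For the measured compounds named here, compound 1 stands nearest, and the step of a number 0.48 log units higher from compound 1 to compound 2 (beyond the scatter) is the only measured step in the set; it concerns a fluorine on the aromatic ring that carries the hydroxymethyl group, a part of the molecule that compound 3 keeps unchanged.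

Compound 3 `Nc1nc(NCCCCc2ccccc2)nc(-c2c(F)cccc2CO)n1` differs from compound 2 by 3-phenylpropyl in place of 4-fluorophenyl on a saturated chain carbon bound to a nitrogen on an aromatic ring. Going by the values given here, no measured step touches this group on the saturated chain carbon, so the two compounds on hand give no guide to its effect in this assay, in either direction. The expectation is therefore a step that may not rise beyond the scatter, with wide uncertainty. Compound 3 is estimated at 4.3, within a range of 3.6 to 5, which means an expected step of a number 0.15 log units lower from compound 2 to compound 3 (within the scatter).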

Compound 3, negative logarithm of the antagonist equilibrium constant: 4.04
Beside the measured number, compound 3's estimate is 0.26 log units above it, and the stated range covers the measured number.
By their numbers in this assay, from the lowest: compounds 1 and 3 (each within the scatter of the next); then compound 2.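

In this assay, the change on the saturated chain carbon bound to a nitrogen on an aromatic ring gives a number 0.41 log units lower from compound 2 to compound 3 (beyond the scatter) and so shows that the number responds to the group at this position. Both groups hold one six-membered aromatic ring of carbon only, and exchanging 4-fluorophenyl for the larger 3-phenylpropyl lowers the number modestly rather than raising it. No measurement on hand explains this drop.

The fluorine and the chain length changed together, so the compounds shown leave open which of the two accounts for the step, a question that a plain phenyl in place of 4-fluorophenyl would help to separate. Also open, from the compounds shown here alone, is how a shorter chain, or an amine on the chain, would read at this position.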